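Benzoate esters on the enone chain: toward compound 4

The source may report more compounds than this note shows. Statements on the series, on what has been measured and on what is new or still open speak of the compounds shown alone.

In a functional assay on SW1573 cells (Homo sapiens) for inhibition, read by sulforhodamine B assay, with a stated time of 48 h (on this read-out higher numbers stand for weaker inhibition of growth and lower numbers for stronger inhibition of growth), compound 1 `O=C(OC/C(=C\c1ccccc1[N+](=O)[O-])C(=O)c1ccccc1)c1ccccc1` gives 4300 nM. Compound 2 `CC(=O)OC/C(=C/c1ccccc1[N+](=O)[O-])C(=O)c1ccccc1` returns only a limit in this assay, > 100000 nM, which is the limit of > 100000 nM in this assay, at which 1 of the 3 values shown sits. Compound 3 `O=C(OC/C(=C/c1ccc(Cl)cc1Cl)C(=O)c1ccccc1)c1ccccc1` gives 29000 nM in this assay; of the two numbers in hand it is the higher one, with compound 1 lying lower by a margin beyond the scatter. Going by the values given here, no step between two measured compounds that differ in a single place is available, so the way from compound 3 to compound 4 rests on analogy alone.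

Compound 4 `O=C(OC/C(=C/c1ccccc1[N+](=O)[O-])C(=O)c1ccccc1)c1ccccc1` has not yet been measured in this assay. It differs from compound 3 by 2-nitrophenyl in place of 2,4-dichlorophenyl on a double-bonded chain carbon bound to a double-bonded chain carbon. Compound 1 and compound 2 carry the same 2-nitrophenyl group as compound 4, but their ester parts and chain geometry differ from those of compound 3 and from each other, so they give no direct guide to the direction. The expected step is therefore modest, a 1.9-fold lower number from compound 3 to compound 4 (0.29 log units; within the scatter), leaning toward a lower number but not clearly beyond the scatter. Compound 4 is estimated at 15000 nM in this assay, within a range of 4000 nM to 60000 nM.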

Compound 4, concentration for 50% growth inhibition: > 100000 nM
Compound 4 gave a limit, no number; the forecaster's own chance of this, stated with the estimate: 10%; at least 6.6-fold (0.82 log units) between middle value and limit.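

In this assay compound 4 gives > 100000 nM, which is a limit and not a number. The exchange of 2,4-dichlorophenyl for 2-nitrophenyl on a double-bonded chain carbon bound to a double-bonded chain carbon now has a direction, an at least 3.4-fold higher number from compound 3 to compound 4 (0.53 log units; beyond the scatter), and this step can only be a lower bound on the true change. Going by these compounds alone, the double bond matters more than the earlier compounds could show, with drawn E geometry in the benzoate series giving an at least 23-fold higher number from compound 1 to compound 4 (1.36 log units; beyond the scatter), a pair that isolates this one feature: the fact that compounds 1 and 4 differ only in the configuration as drawn.

The step between compound 2 and compound 4 cannot be read: the limit of > 100000 nM in this assay, at which 2 of the 4 values shown sit. Open, going by these compounds, are whether E geometry has the same effect with 2,4-dichlorophenyl on the chain, and how an amine or a carboxylic acid in place of the benzoate ester would behave.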